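Methoxy to methyl on the terminal aryl group

A few compounds are considered here, and "the series" means these few. Any claim that something is new, unique, unknown or untested is made for them only; others in the source may bear on it.

In a functional assay on PC-3 cells (Homo sapiens) for cytotoxicity, read by MTT assay, with a stated time of 72 h (on this read-out lower numbers stand for stronger inhibition and higher numbers for weaker inhibition), compound 1 `CNC(=O)c1cc(Oc2ccc(NC(=O)c3nccc(-c4ccccc4)n3)cc2)ccn1` gives 7310 nM and compound 2 `CNC(=O)c1cc(Oc2ccc(NC(=O)c3nccc(-c4ccc(OC)cc4)n3)cc2)ccn1` gives 14200 nM. These two values lie within the scatter of each other, so the series has no clear separation yet. Compound 3 `CNC(=O)c1cc(Oc2ccc(NC(=O)c3nccc(-c4ccc(C)cc4)n3)cc2)ccn1` carries methyl in place of methoxy on an aromatic carbon, para to a large group (methyl in place of methoxy on an aromatic carbon). Within the data shown here, the one measured step that bears on this change is a 1.9-fold higher number from compound 1 to compound 2 (0.29 log units; within the scatter), with methoxy in place of hydrogen on an aromatic carbon. Among the measured compounds shown here, that step stays within the scatter, and no measured step yet involves methyl. In this assay, no shift beyond the scatter is therefore expected in either direction. The expected step is a 1.4-fold lower number from compound 2 to compound 3 (0.15 log units; within the scatter). For compound 3 the estimated value is 10000 nM, with an expected range from 5000 nM to 20000 nM.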

Compound 3, half-maximal inhibitory concentration: 13100 nM
Beside the measured number, compound 3's estimate is 1.3-fold (0.12 log units) below it; the measured number falls inside the stated range.
By their numbers in this assay, from the lowest: compounds 1, 3 and 2 (each within the scatter of the next).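

In this assay the change from 4-methoxyphenyl to 4-methylphenyl gives a 1.1-fold lower number from compound 2 to compound 3 (0.04 log units; within the scatter) and so separates neither group from the other at this place on the ring. Methyl in place of hydrogen gives a 1.8-fold higher number from compound 1 to compound 3 (0.25 log units; within the scatter) on the same aromatic carbon, so methyl, like methoxy, has not moved the number beyond the scatter, and hydrogen, methoxy and methyl remain unresolved here. Nothing at hand explains this flat result.

As far as these compounds go, whether an amine, a carboxylic acid or a longer chain such as butoxy on this carbon would shift the number beyond the scatter remains open. Also open, from the compounds shown here alone, is whether methyl or methoxy on another carbon of this ring would behave the same way.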